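Methyl for dibromomethyl on a brominated lactone core

A few compounds are considered here, and "the series" means these few. Any claim that something is new, unique, unknown or untested is made for them only; others in the source may bear on it.

Of the compounds shown here, two have been measured. Compound 1 `CCC[C@@H](OC(C)=O)C1=C(Br)[C@@](C)(OC)OC1=O` gives 2.4 ug/mL in a functional assay on ZR-75-1 cells (Homo sapiens) for cytotoxicity; on this read-out lower numbers stand for an effect already at smaller amounts and higher numbers for an effect only at larger amounts of compound. Compound 2 `CCC[C@@H](OC(C)=O)C1=C(Br)[C@@](OC)(C(Br)Br)OC1=O` gives 2.8 ug/mL in this assay; this is the higher of the two numbers, yet compound 1 lies within the usual scatter of it. Compound 3 `CCC[C@@H](OC(C)=O)C1=C(Br)[C@](C)(OC)OC1=O` has not been measured. It differs from compound 2 in one place: methyl in place of dibromomethyl on a saturated ring carbon. Among the compounds with values here, with only two compounds and no step between them to lean on, the expected step of a 1.1-fold lower number from compound 2 to compound 3 (0.05 log units; within the scatter) is none beyond the scatter, since compound 1 with the same methyl gives 2.4 ug/mL. Compound 3 is therefore estimated at 2.5 ug/mL, with a range from 1.2 ug/mL to 5.5 ug/mL.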

Compound 3, concentration for half-maximal effect: 4 ug/mL
Beside the measured number, compound 3's estimate is 1.6-fold (0.20 log units) below it; low and high end bracket the measured number.
By their numbers in this assay, from the lowest: compounds 1, 2 and 3 (each within the scatter of the next).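

In this assay, methyl in place of dibromomethyl on the saturated ring carbon gives a 1.4-fold higher number from compound 2 to compound 3 (0.15 log units; within the scatter), so this exchange does not separate from the scatter. The drawn configuration at that ring carbon also stays within the scatter, with a 1.7-fold higher number from compound 1 to compound 3 (0.22 log units; within the scatter). This pair is the one comparison that speaks to configuration at this position: the fact that compounds 1 and 3 differ only in the configuration as drawn

The compounds shown leave open whether an amine or a longer chain on this ring carbon would give a step beyond the scatter. They also leave open how compound 2 would read with the other configuration there.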